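Removing a Catechol Hydroxy From a Prenylated Chalcone

The compounds below may be only part of what the source reports. "The series", "measured", "known", "first", "only" and "open" are said of these compounds alone.

Three chalcones were measured in a functional assay on RAW264.7 cells (Mus musculus) for inhibition; a higher number here means a weaker inhibitor, a lower number a stronger inhibitor. Compound 1 `CC(C)=CCC/C(C)=C/Cc1c(O)c2c(c(/C=C/C(=O)c3ccc(O)c(O)c3)c1O)OC(C)(C)C=C2` gives 9500 nM. Compound 2 `COc1cc(C(=O)/C=C/c2cc(OC)c(OC)c(OC)c2)ccc1O` gives 4190 nM, and compound 3 `COc1cccc(C(=O)/C=C/c2cc(OC)c(OC)c(OC)c2)c1` gives 2880 nM. Compound 1 stands highest of the three. How the core of compound 1 differs from that of compound 2 is not broken down here. Between compound 2 and compound 3 the change is hydrogen in place of hydroxy on an aromatic carbon, and it made a 1.5-fold lower number from compound 2 to compound 3 (0.16 log units; within the scatter).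

Compound 4 `CC(C)=CCC/C(C)=C/Cc1c(O)c2c(c(/C=C/C(=O)c3ccc(O)cc3)c1O)OC(C)(C)C=C2` has not been measured. It differs from compound 1 by hydrogen in place of hydroxy on an aromatic carbon. This is the same kind of change as from compound 2 to compound 3, but the place differs: here it is ortho to a hydroxy group and meta to a large group, whereas there it was ortho to a methoxy group and para to a large group. Resting on the step of compound 2 to compound 3, a 1.5-fold lower number from compound 2 to compound 3 (0.16 log units; within the scatter), a step of a 1.3-fold lower number from compound 1 to compound 4 (0.10 log units; within the scatter) is expected. Compound 4 is therefore expected to give 7500 nM, likely between 3000 nM and 20000 nM.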

Compound 4, half-maximal inhibitory concentration: 7600 nM
For compound 4 the middle estimate is 1.0-fold (0.01 log units) below the measured one; the measured number falls inside the stated range.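

In this assay, going from 3,4-dihydroxyphenyl to 4-hydroxyphenyl gave a 1.3-fold lower number from compound 1 to compound 4 (0.10 log units; within the scatter). The same change therefore read alike on the two cores, although its place on the ring differs: the same change on two cores in this assay, a 1.5-fold lower number (0.16 log units; within the scatter) from compound 2 to compound 3 and a 1.3-fold lower number (0.10 log units; within the scatter) from compound 1 to compound 4, 1.2-fold (0.07 log units) apart, within the scatter of two such steps
This shows that in both pairs the hydroxy could give way to hydrogen without a step beyond the scatter, but it does not show that the change has a real effect of its own, or that it would carry to any further core.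

The compounds shown leave open whether an amine or a carboxylic acid in place of that hydroxy would read alike. They also leave open what replacing the remaining hydroxy of the 4-hydroxyphenyl group would do.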